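Isobutyl to sec-butyl on the phenylsulfonyl core

A few compounds are considered here, and "the series" means these few. Any claim that something is new, unique, unknown or untested is made for them only; others in the source may bear on it.

Measured so far:
compound 1, `CC(=O)c1ccc(NC(=O)C(CC(C)C)N(C(=O)c2ccccc2)S(=O)(=O)c2ccc([N+](=O)[O-])cc2)cc1`, 54.2%
compound 2, `CCC(C)C(C(=O)Nc1ccc(C(C)=O)cc1)N(C(=O)c1ccccc1)S(=O)(=O)c1ccc([N+](=O)[O-])cc1`, 31.7%
compound 3, `CC(=O)c1ccc(NC(=O)C(CC(C)C)N(C(=O)c2ccccc2)S(=O)(=O)c2ccccc2)cc1`, 33.7%

The three measured compounds share the anilide, benzoyl and sulfonyl parts and differ in two places. In a functional assay for inhibition, read by spectrophotometry, with a stated time of 20 min, tested at 2 mg/mL (a lower number here means a weaker effect, a higher number a stronger effect of the compound at the concentration tested), compound 1 gives 54.2%, the highest of the three numbers. Compound 2 differs from compound 1 by sec-butyl in place of isobutyl on a saturated chain carbon bound to an amide-type nitrogen and a carbonyl carbon, and the step is a number 22.5 percentage points lower from compound 1 to compound 2 (beyond the scatter). Compound 3 differs from compound 1 by hydrogen in place of nitro on an aromatic carbon, and that step is a number 20.5 percentage points lower from compound 1 to compound 3 (beyond the scatter). Compound 2 and compound 3 lie within the scatter of each other, so no order between them is claimed.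

Compound 4, `CCC(C)C(C(=O)Nc1ccc(C(C)=O)cc1)N(C(=O)c1ccccc1)S(=O)(=O)c1ccccc1`, is not yet measured. For the measured compounds named here, it differs from compound 3 by sec-butyl in place of isobutyl on a saturated chain carbon bound to an amide-type nitrogen and a carbonyl carbon, which is the same change as the one from compound 1 to compound 2, made at the same place; the two cores differ by hydrogen in place of nitro on an aromatic carbon. Going by the values given here, only one instance of this change has been measured, so whether it carries over to the phenylsulfonyl core is open. Taken as a guide, it leads to an expected step of a number 19.7 percentage points lower from compound 3 to compound 4 (beyond the scatter), estimated to be of similar size and uncertain because the only precedent is a number 22.5 percentage points lower from compound 1 to compound 2 (beyond the scatter) on a different core. Compound 4 is thus expected to give about 14% in this assay, with a likely range from 0% to 30%.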

Compound 4, a percentage reported as inhibition, at one concentration (the size of the read-out at that concentration, not a potency): 11.4%
For compound 4 the middle estimate is 2.6 percentage points above the measured one; low and high end bracket the measured number.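

In this assay, sec-butyl in place of isobutyl on a saturated chain carbon bound to an amide-type nitrogen and a carbonyl carbon gives a number 22.3 percentage points lower from compound 3 to compound 4 (beyond the scatter), so the change carries over to the core of compound 3 with its size kept: the same change on two cores in this assay, a number 22.5 percentage points lower (beyond the scatter) from compound 1 to compound 2 and a number 22.3 percentage points lower (beyond the scatter) from compound 3 to compound 4, 0.2 percentage points apart, within the scatter of two such steps. Hydrogen in place of nitro on an aromatic carbon gives a number 20.3 percentage points lower from compound 2 to compound 4 (beyond the scatter), and this change likewise holds its size when the isobutyl is exchanged for sec-butyl: the same change on two cores in this assay, a number 20.5 percentage points lower (beyond the scatter) from compound 1 to compound 3 and a number 20.3 percentage points lower (beyond the scatter) from compound 2 to compound 4, 0.2 percentage points apart, within the scatter of two such steps. The two changes thus behave independently of each other across these four compounds, but that rests on one pair of cores and on a read-out at a single concentration, so it shows neither a general rule for the series nor a difference in potency, and it gives no reason for either step.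

Still open, as far as these compounds go, is whether the same independence holds for other groups on the aromatic carbon, such as an amine or a carboxylic acid, or for a longer chain in place of the isobutyl and sec-butyl. Also open, from the compounds shown here alone, is whether these steps keep their size when the anilide or benzoyl parts shared by all four compounds are changed.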